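Taking the hydroxy group off compound 3

This account rests on a few compounds, and the source may have more. Where it says the series, first, only, none or still open, it means among the compounds named here.

In a functional assay on U-251 cells (Homo sapiens) for antiproliferative activity, read by sulforhodamine B assay, with a stated time of 48 h (on this read-out higher numbers stand for weaker inhibition of growth and lower numbers for stronger inhibition of growth), compound 3 `CCCCCC[C@@H](O)C/C=C\CCCCCCCC(=O)N1CCOCC1` gives 33.1 ug/mL, the highest of three numbers and so the weakest growth inhibition. Compound 1 `CCCCCC[C@@H](O)C/C=C\CCCCCCCC(=O)N[C@@H](C)c1ccccc1` gives 3.6 ug/mL and compound 2 `CCCCCCCC/C=C\CCCCCCCC(=O)N1CCCC1` gives 3.8 ug/mL. Compound 4 `CCCCCCCC/C=C\CCCCCCCC(=O)N1CCOCC1` has hydrogen in place of hydroxy on a saturated chain carbon bound to two saturated chain carbons. Within the data shown here, no measured step isolates this change. Among the measured compounds shown here, the one measured step, a 9.2-fold higher number from compound 1 to compound 3 (0.96 log units; beyond the scatter), is modest and lies elsewhere, on a carbonyl carbon. Compound 2 also lacks the hydroxy and reaches 3.8 ug/mL, though its amide differs too. A smaller drop is therefore expected, a 2.4-fold lower number from compound 3 to compound 4 (0.37 log units; beyond the scatter). For compound 4 the estimate is 14 ug/mL, with an expected range of 5 ug/mL to 40 ug/mL.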

Compound 4, concentration for 50% growth inhibition: 2.8 ug/mL
The estimate for compound 4 lay 5.0-fold (0.70 log units) above the measured number; the measured number lies below the stated range.
By their numbers in this assay, from the lowest: compounds 4, 1 and 2 (each within the scatter of the next); then compound 3.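

In this assay, 1-hydroxyheptyl to heptyl on the morpholin-4-yl amide proves a large change, a 12-fold lower number from compound 3 to compound 4 (1.07 log units; beyond the scatter), so this chain carbon matters a great deal for growth inhibition in that amide. Once the hydroxy is gone, morpholin-4-yl in place of pyrrolidin-1-yl on the carbonyl carbon gives a 1.4-fold lower number from compound 2 to compound 4 (0.13 log units; within the scatter), which does not separate the two amides. Nothing available explains the size of the hydroxy step. As far as these compounds go, whether a methoxy or an amine on this chain carbon would behave like the hydroxy or like hydrogen remains open.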